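Swapping the amine's aryl group in a weakly cytotoxic series

A few compounds are considered here, and "the series" means these few. Any claim that something is new, unique, unknown or untested is made for them only; others in the source may bear on it.

Compound 1 `O=C(/C=C\Nc1ccc2cc[nH]c2c1)c1nc(-c2ccc(C(F)(F)F)cc2)n2ccccc12`: > 30000 nM
Compound 2 `COc1ccc(N/C=C\C(=O)c2nc(-c3ccc(F)cc3)n3ccccc23)cc1`: 19200 nM

Both measured compounds share one core and differ in the aryl group on the amine nitrogen and in the substituent on the pendant phenyl ring. In a functional assay on A549 cells (Homo sapiens) for cytotoxicity, read by MTT assay, with a stated time of 48 h (on this read-out higher numbers stand for weaker inhibition and lower numbers for stronger inhibition), compound 1 gives only a limit, > 30000 nM, so its true value is not known as a number. Compound 1 thus sits at the limit of > 30000 nM in this assay, at which 1 of the 2 values shown sits. Compound 2, with a methoxyphenyl group on the amine nitrogen and a fluorophenyl on the core, gives 19200 nM in this assay, a weak but measurable value. Among the compounds with values here, no step between these two is computed. Several groups change at once between them.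

Compound 3 `O=C(/C=C\Nc1ccc(Cl)cc1)c1nc(-c2ccc(C(F)(F)F)cc2)n2ccccc12` differs from compound 1 in one place: 4-chlorophenyl in place of 1H-indol-6-yl on an amine nitrogen. Nothing measured here points to a large effect of this exchange, so the step from compound 1 to compound 3 is expected to be small, within the scatter or slightly towards stronger inhibition, as an at least 1.2-fold lower number from compound 1 to compound 3 (0.07 log units; that floor lies within the scatter) expresses. Compound 3 is estimated at 25000 nM, with a range from 8000 nM to 100000 nM.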

Compound 3, half-maximal inhibitory concentration: 18500 nM
Estimate against measurement, compound 3: 1.4-fold (0.13 log units) above; measured number inside the range.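

Exchanging 1H-indol-6-yl for 4-chlorophenyl on the amine nitrogen gives, in this assay, an at least 1.6-fold lower number from compound 1 to compound 3 (0.20 log units; that floor lies within the scatter). Within the data shown here, this is the first comparison here in which only one place changes, and it shows that this amine nitrogen can carry a different aryl group and still give a measurable number, though the printed floor alone does not establish a change beyond the scatter. As far as these compounds go, the true size of the step stays unknown because compound 1 carries only a limit: the limit of > 30000 nM in this assay, at which 1 of the 3 values shown sits.

The compounds shown leave open how an unsubstituted phenyl, or an aryl ring carrying a carboxylic acid or an amine, would read on this nitrogen. From the compounds shown here alone, it also remains open whether the same exchange would give a similar step with the fluorophenyl of compound 2 on the core.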